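Sulfonyl Aryl Swap on a Hexyl-Linked Bromobenzylamine

This account rests on a few compounds, and the source may have more. Where it says the series, first, only, none or still open, it means among the compounds named here.

The measured compounds and their values:
Compound 1, `O=S(=O)(NCCCCCCNCc1ccc(Br)cc1)c1ccccc1F`, 13300 nM
Compound 2, `O=S(=O)(NCCCNCc1cccc2ccccc12)c1cc(C(F)(F)F)cc(C(F)(F)F)c1`, 2800 nM
Compound 3, `COc1ccc(CNCCCNS(=O)(=O)c2cc(C(F)(F)F)cc(C(F)(F)F)c2)cc1`, 2500 nM

In a functional assay on MIA PaCa-2 cells (Homo sapiens) for inhibition, read by MTT assay, with a stated time of 72 h (a lower number here means a stronger inhibitor of growth, a higher number a weaker inhibitor of growth), compound 1 gives 13300 nM, the highest of the three numbers; compound 2 and compound 3 both sit beyond the scatter below it. Between compound 2 and compound 3 the change was at the other end of the molecule, and the step of a 1.1-fold lower number from compound 2 to compound 3 (0.05 log units; within the scatter) stayed within the scatter.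

Compound 4, `Cc1ccc(S(=O)(=O)NCCCCCCNCc2ccc(Br)cc2)cc1`, has not yet been measured. It differs from compound 1 in one place: 4-methylphenyl in place of 2-fluorophenyl on a sulfonyl sulfur. Among the measured compounds shown here, none of the measured steps touches the group on the sulfonyl sulfur, so the only bearing step, the one from compound 2 to compound 3, shows just that a swap elsewhere left the number unchanged. With no direct guide, the expectation for compound 4 is a number close to that of compound 1, with no step beyond the scatter in either direction. The step of a 1.0-fold lower number from compound 1 to compound 4 (0.01 log units; within the scatter) is therefore expected to be small. Compound 4 is estimated at 13000 nM, with a range from 5000 nM to 35000 nM.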

Compound 4, concentration for 50% growth inhibition: 12300 nM
Beside the measured number, compound 4's estimate is 1.1-fold (0.02 log units) above it; the measured number falls inside the stated range.
By their numbers in this assay, from the lowest: compounds 3 and 2 (each within the scatter of the next); then compounds 4 and 1 (each within the scatter of the next).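

Among the compounds shown here, the step on the sulfonyl sulfur, a 1.1-fold lower number from compound 1 to compound 4 (0.03 log units; within the scatter), is the first in this assay to touch this position. For the compounds shown here, the only earlier step, between compound 2 and compound 3, concerned the group at the other end of the molecule. With the hexyl chain and the bromobenzylamine held the same, a 2-fluorophenyl and a 4-methylphenyl, each with one six-membered aromatic ring of carbon only, give values within the scatter of each other, so this pair shows no sensitivity in this assay to that particular exchange. The compounds shown offer no measurement that would explain this result.

Compound 2 and compound 3 differ from compound 1 and compound 4 in more than one place, so their values cannot be assigned to either the chain or the group on the sulfonyl sulfur. As far as these compounds go, it remains open whether a phenyl ring carrying two trifluoromethyl groups, a pyridine or a ring bearing a carboxylic acid on the sulfonyl sulfur of this hexyl-linked compound would move the number beyond the scatter.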